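This account rests on a few compounds, and the source may have more. Where it says the series, first, only, none or still open, it means among the compounds named here.

Measured so far in a physicochemical assay for solubility, in phosphate buffer, at pH 7.4; on this read-out lower numbers stand for lower solubility and higher numbers for higher solubility:
compound 1, `N/C(=N/O)c1ccc2[nH]c(-c3cccc(-c4ccccc4O)c3O)cc2c1`, gives 380000 nM
compound 2, `CC(C)ONC(=N)c1ccc2[nH]c(-c3cccc(-c4ccccc4O)c3O)cc2c1`, gives 25000 nM

Compound 2 stands at the lower of the two numbers. Compound 3, `CC(C)(C)ONC(=N)c1ccc2[nH]c(-c3cccc(-c4ccccc4O)c3O)cc2c1`, differs from compound 2 by methyl in place of hydrogen on a saturated chain carbon bound to an oxygen on an unsaturated carbon and two saturated chain carbons. Among the compounds with values here, only one measured step bears on this region of the shared core, a 15-fold lower number from compound 1 to compound 2 (1.18 log units; beyond the scatter), and that change was a far larger reworking of the group than the single added methyl here. A modest further decrease is therefore expected, a 2.1-fold lower number from compound 2 to compound 3 (0.32 log units; beyond the scatter), with a fair chance it stays within the scatter. Compound 3 is estimated at 12000 nM, with a range from 4000 nM to 40000 nM.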

Compound 3, solubility: < 10000 nM
Compound 3 ended at the assay's limit; the forecaster's own chance of this, stated with the estimate: 5%; at least 1.2-fold (0.07 log units) between middle value and limit.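

In this assay compound 3 gives < 10000 nM, which is a limit of the assay and not a number: the limit of < 10000 nM in this assay, at which 1 of the 3 values shown sits. Isopropoxy to tert-butoxy, a single added methyl, is enough for an at least 2.5-fold lower number from compound 2 to compound 3 (0.39 log units; beyond the scatter), so even this small change on the saturated chain carbon moves the read-out beyond the scatter. The whole group change gives an at least 38-fold lower number from compound 1 to compound 3 (1.57 log units; beyond the scatter).

On these data alone, how far the true value of compound 3 lies past the limit remains open. So does where a group such as methoxy or ethoxy, in place of isopropoxy, would fall.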